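The compounds below may be only part of what the source reports. "The series", "measured", "known", "first", "only" and "open" are said of these compounds alone.

Compound 1 `COc1ccc(C(=O)/C=C/c2cc3ccccc3[nH]c2=O)cc1` and compound 2 `O=C(/C=C/c1cc2ccccc2[nH]c1=O)c1ccc(O)cc1` share the same core and differ only at one oxygen on the aromatic ring. In a functional assay on COLO 205 cells (Homo sapiens) for cytotoxicity, read by sulforhodamine B assay, with a stated time of 24 h (on this read-out higher numbers stand for weaker inhibition of growth and lower numbers for stronger inhibition of growth), compound 1 gives 13400 nM, and in the same assay compound 2 gives 19700 nM. The step of a 1.5-fold higher number from compound 1 to compound 2 (0.17 log units; within the scatter) is within the scatter, so compound 2, though it carries the higher of the two numbers, cannot be separated from compound 1. Compound 3 `O=C(/C=C/c1cc2ccccc2[nH]c1=O)c1ccc(Cl)cc1` differs from compound 2 as follows: chloro in place of hydroxy on an aromatic carbon. For the measured compounds named here, the only measured step concerns a different exchange on that same carbon and was within the scatter; no measured step involves chloro. On this basis a step beyond the scatter is not expected in this assay, and the number for compound 3 is estimated at 12000 nM, within a range of 4000 nM to 40000 nM. The expected change a 1.6-fold lower number from compound 2 to compound 3 (0.22 log units; within the scatter) therefore stays small.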

Compound 3, concentration for total growth inhibition: 51300 nM
For compound 3 the middle estimate is 4.3-fold (0.63 log units) below the measured one, and the stated range ends below it.
By their numbers in this assay, from the lowest: compounds 1 and 2 (each within the scatter of the next); then compound 3.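

At this carbon, para to a large group, the position proves sensitive to the exchange in this assay: replacing hydroxy with chloro gives a 2.6-fold higher number from compound 2 to compound 3 (0.42 log units; beyond the scatter), and replacing methoxy with chloro gives a 3.8-fold higher number from compound 1 to compound 3 (0.58 log units; beyond the scatter). The two oxygen-linked groups could not be separated, whereas chloro stands apart from both, on the side of weaker inhibition of growth. No measurement is available here that would account for this difference.

Going by these compounds, whether an amine or a carboxylic acid on this carbon would stay with hydroxy and methoxy or fall with chloro remains open. For the compounds shown here, with chloro as the only group lacking oxygen, it is also unclear whether the shift is specific to chloro or would be shared by a methyl or a bromo group.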